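Amide nitrogen substituent in a phenoxy-acetamide agonist series

A few compounds are considered here, and "the series" means these few. Any claim that something is new, unique, unknown or untested is made for them only; others in the source may bear on it.

Three measured compounds share the aryloxy-acetamide core. Compound 1 `CCN(Cc1cccs1)C(=O)C(C)Oc1ccc(C)cc1` gives 889 nM in an assay on HEK293 cells for agonist activity at transient receptor potential cation channel subfamily M member 8 (Homo sapiens), read by fluorescence and calcium flux, with a stated time of 15 min; on this read-out higher numbers stand for an effect only at larger amounts of compound and lower numbers for an effect already at smaller amounts. Compound 3 `CCN(Cc1ccccc1)C(=O)COc1ccc(C)cc1` gives 1880 nM in this assay. Compound 2 `Cc1ccc(OCC(=O)N(Cc2cccs2)C2COC2)cc1`, which carries oxetan-3-yl on the amide-type nitrogen, gives 23000 nM in this assay and stands at the highest of the three numbers: compound 3 is its nearest neighbour with a lower number, and compound 1 is furthest with a still lower number, both gaps being beyond the usual scatter. The two compounds with a small saturated chain on the amide-type nitrogen thus sit clearly lower than compound 2.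

Compound 4 `Cc1ccc(OCC(=O)N(Cc2cccs2)c2cnn(C)c2)cc1` is not yet measured. It differs from compound 2 in one place (1-methyl-1H-pyrazol-4-yl in place of oxetan-3-yl on an amide-type nitrogen). Among the compounds with values here, no measured pair shows this exchange, so its size cannot be read from the data. Since compound 2 gives 23000 nM and the other nitrogen substituents give lower numbers, a step down from compound 2 to compound 4 is expected, of moderate size, though it may well stay within the scatter; the expected step is a 2.9-fold lower number from compound 2 to compound 4 (0.46 log units; beyond the scatter). Compound 4 is therefore estimated at 8000 nM in this assay, in a range from 2000 nM to 30000 nM.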

Compound 4, half-maximal effective concentration: 63000 nM
Compound 4: middle estimate off by 7.9-fold (0.90 log units), on the low side, outside the stated range (above it).
By their numbers in this assay, from the lowest: compound 1; then compound 3; then compound 2; then compound 4.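

Within the data shown here, with the rest of the molecule held fixed, 1-methyl-1H-pyrazol-4-yl in place of oxetan-3-yl on the amide-type nitrogen gives a 2.7-fold higher number from compound 2 to compound 4 (0.44 log units; beyond the scatter) in this assay, the first step at this position that can be read directly. The substituent on this nitrogen therefore moves the read-out on its own, and in this one pair the five-membered aromatic ring, with its larger heavy-atom count and additional hydrogen-bond acceptor, goes with an effect only at larger amounts of compound than the four-membered non-aromatic ring. Nothing available accounts for the step, so the pair records a direction for this single exchange and no more.

The compounds shown leave open whether the higher number follows from aromatic character, from ring size or from the ring hetero atoms, since all of these change together in this exchange. A plain phenyl ring, a cyclobutyl ring or a longer chain such as n-propyl on the same nitrogen, with the rest of compound 2 unchanged, would help separate these readings.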